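Series notes: hydrogen in place of dimethylamino

The compounds below may be only part of what the source reports. "The series", "measured", "known", "first", "only" and "open" are said of these compounds alone.

Measured so far:
- compound 1 `CN(C)c1ccc(/C=C/C=C/C(=O)N2CCCCC2)cc1` gives 13.4%
- compound 2 `COc1cc(OC)c(/C=C/C=C/C(=O)N2CCCCC2)c(OC)c1` gives 77.1%
- compound 3 `COc1cc(/C=C/C=C/C(=O)N2CCCCC2)ccc1O` gives 55.5%

In an assay for inhibition of Polyunsaturated fatty acid 5-lipoxygenase (Homo sapiens), read by spectrophotometry, tested at 20 uM (a higher number here means more inhibition at the concentration tested (going by the name of the read-out), a lower number less inhibition), compound 1 stands lowest of the three numbers. Compound 3 is the nearest to it, its number higher by an amount beyond the scatter; compound 2 is the furthest, its number higher by a larger amount, also beyond the scatter. Neither pair is a single-point change from compound 1, so these two values show only that other substitution patterns on the aromatic ring of the shared core reach clearly higher inhibition than compound 1 does.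

Compound 4 `O=C(/C=C/C=C/c1ccccc1)N1CCCCC1` is the unmeasured case. It differs from compound 1 as follows: hydrogen in place of dimethylamino on an aromatic carbon.

Going by the values given here, no step of this kind exists between measured compounds, so the size of the change in this assay is open. Compound 1 stands lowest, and both substituted rings measured so far stand above it, which gives some ground to expect a rise rather than a fall; the step from compound 1 to compound 4 is expected to be modest but beyond the scatter, a number 16.6 percentage points higher from compound 1 to compound 4 (beyond the scatter). Compound 4 is therefore estimated at 30%, within a range from 10% to 55%.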

Compound 4, a percentage reported as inhibition, at one concentration (the size of the read-out at that concentration, not a potency): 36.3%
The estimate for compound 4 lay 6.3 percentage points below the measured number; the range from low to high includes it.
By their numbers in this assay, from the lowest: compound 1; then compound 4; then compound 3; then compound 2.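

In this assay, going by these compounds alone, this is the first step that changes one place alone: hydrogen in place of dimethylamino on an aromatic carbon, para to a large group, gives a number 22.9 percentage points higher from compound 1 to compound 4 (beyond the scatter). The direction of the change at this position can therefore be read directly, and losing the dimethylamino group raises the number rather than lowering it, with compound 4 at 36.3% as the reference for the shared core without that substituent. No measurement at hand bears on the cause of this rise.

Compound 2 and compound 3 each differ from compound 1 and from compound 4 in more than one place, so no steps can be read from them, and the contribution of each of their ring substituents stays unresolved. On these data alone, it remains open whether the rise is particular to dimethylamino or whether other groups at this same position, such as a primary amine, a chlorine atom or a carboxylic acid, would stand above or below compound 4 in this assay.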